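The compounds below may be only part of what the source reports. "The series", "measured", "known", "first", "only" and "open" are said of these compounds alone.

Of the compounds shown here, two have been measured so far in a functional assay on the whole organism with Rattus norvegicus as the target, at a dose of 20 mg/kg by the oral route; on this read-out higher numbers stand for more inhibition at the one dose given (going by the name of the read-out) and lower numbers for less inhibition. Compound 1 `O=C(/C=C1\CCc2ccc(F)cc21)NCCO` gives 78% in this assay, while compound 2 `CON(C)C(=O)/C=C1\CCc2ccc(F)cc21` gives 14%. Among the measured compounds shown here, compound 2 therefore stands lowest of the two numbers, and the only step recorded so far, a number 64 percentage points lower from compound 1 to compound 2 (beyond the scatter), accompanies the exchange of (2-hydroxyethyl)amino for methoxy(methyl)amino on the carbonyl carbon.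

Compound 3 `CCCNC(=O)/C=C1\CCc2ccc(F)cc21` is the next compound in the series, still unmeasured. It differs from compound 2 in one place: propylamino in place of methoxy(methyl)amino on a carbonyl carbon. This change undoes the part of the earlier step that removed the amide hydrogen, since propylamino, like (2-hydroxyethyl)amino in compound 1, carries a hydrogen on nitrogen, though it lacks the hydroxyl of compound 1.

The step from compound 1 to compound 2 is the only one that bears on this change, and it was large. A rise well beyond the scatter is therefore expected, written as a number 44 percentage points higher from compound 2 to compound 3 (beyond the scatter), though not a full return to compound 1. Compound 3 is estimated at 58%, with a range from 30% to 82%.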

Compound 3, a percentage reported as inhibition, in the whole organism at one dose (the size of the read-out at that dose, not a potency): 36%
For compound 3 the middle estimate is 22 percentage points above the measured one; the measured number falls inside the stated range.
By their numbers in this assay, from the lowest: compound 2; then compound 3; then compound 1.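

Read against the earlier compounds, this result shows that the hydrogen on the amide nitrogen does not by itself account for the high number of compound 1: in this assay, the move to propylamino on the carbonyl carbon gives a number 22 percentage points higher from compound 2 to compound 3 (beyond the scatter) and recovers only part of the earlier drop. The hydroxy group of the (2-hydroxyethyl)amino chain now also counts in its own right, since the exchange of hydroxy for methyl on the saturated chain carbon gives a number 42 percentage points lower from compound 1 to compound 3 (beyond the scatter) at the same chain length, a larger step than the one from methoxy(methyl)amino to propylamino. No measurement here bears on why either change moves the number as it does.

The compounds shown leave open whether the hydroxy can be replaced on that saturated chain carbon, for instance by a methoxy group, an amine or a carboxylic acid, and whether a longer chain carrying a terminal hydroxy would hold the number of compound 1. They also leave open how much of the step to propylamino belongs to the amide hydrogen and how much to the loss of the methoxy oxygen, as the two changes occur together.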